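Aryl Amide Variation in a Glutathione S-Transferase Inhibitor Series

This account rests on a few compounds, and the source may have more. Where it says the series, first, only, none or still open, it means among the compounds named here.

Compound 3 `Cc1ccc(NC(=O)CCC(=O)OCCCCCCSc2ccc([N+](=O)[O-])c3nonc23)cc1` gives 6800 nM in an assay on isolated protein for inhibition of glutathione S-transferase P (Homo sapiens), with a stated time of 10 min (on this read-out higher numbers stand for weaker inhibition and lower numbers for stronger inhibition), and it stands alongside compound 1 `O=C(CCC(=O)OCCCCCCSc1ccc([N+](=O)[O-])c2nonc12)Nc1ccccc1` at 10200 nM and compound 2 `O=C(CCC(=O)OCCCCCCSc1ccc([N+](=O)[O-])c2nonc12)Nc1ccccc1F` at 9890 nM, all three numbers within the scatter of one another. Compound 4 `O=C(CCC(=O)OCCCCCCSc1ccc([N+](=O)[O-])c2nonc12)Nc1ccc(F)c(Cl)c1` carries 3-chloro-4-fluorophenyl in place of 4-methylphenyl on an amide-type nitrogen. For the measured compounds named here, three measured steps bear on this change: fluoro in place of hydrogen on an aromatic carbon gave a 1.0-fold lower number from compound 1 to compound 2 (0.01 log units; within the scatter), methyl in place of hydrogen gave a 1.5-fold lower number from compound 1 to compound 3 (0.18 log units; within the scatter), and the swap of the whole aryl group gave a 1.5-fold lower number from compound 2 to compound 3 (0.16 log units; within the scatter). None of these left the scatter, so for compound 4 no step beyond the scatter is expected, with a slight drift toward a higher number considered possible, a 1.3-fold higher number from compound 3 to compound 4 (0.12 log units; within the scatter). Compound 4 is therefore estimated at 9000 nM, within 4500 nM to 18000 nM.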

Compound 4, half-maximal inhibitory concentration: 9850 nM
Estimate against measurement, compound 4: 1.1-fold (0.04 log units) below; low and high end bracket the measured number.
By their numbers in this assay, from the lowest: compounds 3, 4, 2 and 1 (each within the scatter of the next).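

With two halogens on the ring, 3-chloro-4-fluorophenyl on the amide-type nitrogen still leaves this assay unmoved beyond the scatter against each aryl group measured so far (a 1.4-fold higher number from compound 3 to compound 4 (0.16 log units; within the scatter); a 1.0-fold lower number from compound 2 to compound 4 (0.00 log units; within the scatter); a 1.0-fold lower number from compound 1 to compound 4 (0.02 log units; within the scatter)). The four compounds thus show that this position tolerates a ring with one or two substituents without a step that can be told from the scatter. No supporting evidence is available to explain this flat result.

From the compounds shown here alone, whether an amine or a carboxylic acid on this ring would produce a larger step remains open. So does the effect of a longer chain in the rest of the molecule.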